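Swapping the aryl sulfonamide: from methylphenyl to fluorophenyl

The source may hold more compounds than are shown below. What is called first, only, known or untested is meant among the compounds shown, and "the series" means these compounds.

Three members of one sulfonamide series have numbers in an assay on MDA-MB-231 cells for displacement of a labelled ligand from C-X-C chemokine receptor type 4 (Homo sapiens), read by fluorescence and microscopy, with stated times of 10 min and 30 min; a lower number here means that less compound is needed, a higher number that more compound is needed for the effect. Compound 1 `Cc1ccccc1C(=O)NCc1ccc(CNS(=O)(=O)c2ccc(Cl)cc2)cc1` gives 1 nM, compound 2 `Cc1ccccc1C(=O)NCc1ccc(CNS(=O)(=O)c2ccccc2C)cc1` gives 10 nM, and compound 3 `COc1ccccc1C(=O)NCc1ccc(CNS(=O)(=O)c2cccc(C)c2)cc1` gives 1000 nM. Compound 2 therefore stands second highest of the three, with compound 1 at a lower number and compound 3 far higher. Going by the values given here, the one single-point step measured so far, a 10-fold higher number from compound 1 to compound 2 (1.00 log units; beyond the scatter), was brought about by the 2-methylphenyl entering in place of the 4-chlorophenyl.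

Compound 4 `Cc1ccccc1C(=O)NCc1ccc(CNS(=O)(=O)c2ccc(F)cc2)cc1` has not yet been measured. It differs from compound 2 in one place: 4-fluorophenyl in place of 2-methylphenyl on a sulfonyl sulfur. This change runs the measured step largely in reverse, since the 4-fluorophenyl of compound 4 resembles the 4-chlorophenyl of compound 1 more than the 2-methylphenyl of compound 2 does. A lower number than that of compound 2 is therefore expected, though not necessarily as low as compound 1, because a 10-fold higher number from compound 1 to compound 2 (1.00 log units; beyond the scatter) need not be fully recovered. For compound 4 the expected step is a 3.3-fold lower number from compound 2 to compound 4 (0.52 log units; beyond the scatter). For compound 4 the estimate in this assay is 3 nM, within a range of 1 nM to 15 nM.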

Compound 4, effective concentration (reported as EC, without a stated level of effect): 10 nM
Compound 4: the middle estimate sits 3.3-fold (0.52 log units) below what was measured, and the stated range covers the measured number.
By their numbers in this assay, from the lowest: compound 1; then compounds 2 and 4 (each within the scatter of the next); then compound 3.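

In this assay, the 4-fluorophenyl and the 2-methylphenyl on the sulfonyl sulfur cannot be told apart, with no change at the digits printed from compound 2 to compound 4 (within the scatter). The identity of the halogen matters at this position: fluoro in place of chloro on an aromatic carbon gives a 10-fold higher number from compound 1 to compound 4 (1.00 log units; beyond the scatter), matching a 10-fold higher number from compound 1 to compound 2 (1.00 log units; beyond the scatter), so among these sulfonamides only the 4-chlorophenyl of compound 1 stands apart. No measurement at hand accounts for this difference between chloro and fluoro.

The compounds shown leave open how a 4-bromophenyl or a 4-methoxyphenyl on the sulfonyl sulfur would compare with the 4-chlorophenyl of compound 1. Compound 3 differs from the others in more than one place, and the separate contributions of its methoxy group and its sulfonyl aryl group remain unresolved.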